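This account rests on a few compounds, and the source may have more. Where it says the series, first, only, none or still open, it means among the compounds named here.

Measured compounds:
Compound 1, `COc1ccc(-c2cc(=O)c3c(OC)cc(OC)cc3[nH]2)cc1` — in a functional assay on HepG2 cells (Homo sapiens) for antiproliferative activity, with a stated time of 72 h (on this read-out higher numbers stand for an effect only at larger amounts of compound and lower numbers for an effect already at smaller amounts), compound 1 gives > 31100 nM, which is a limit of the assay and not a number.
Compound 2, `COc1ccc(-c2cc(=O)c3c(OC)cc(OC)cc3n2S(=O)(=O)c2ccc(C)c([N+](=O)[O-])c2)cc1` — in this assay compound 2 gives > 51700 nM, again only a limit.
Compound 3, `COc1ccc(-c2cc(=O)c3c(OC)cc(OC)cc3n2S(=O)(=O)c2ccc(Cl)cc2)cc1` — in this assay compound 3 gives > 34400 nM, also only a limit.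

Compound 3 thus stands at a limit, as do the two other compounds shown, so no ordering among the three can be read. The step that the two limits leave unreadable from compound 1 to compound 3 and the step that the two limits leave unreadable from compound 2 to compound 3 are both unreadable, since each end sits at a limit, as the limit of > 31100 nM in this assay, at which 1 of the 3 values shown sits, the limit of > 34400 nM in this assay, at which 1 of the 3 values shown sits, and the limit of > 51700 nM in this assay, at which 1 of the 3 values shown sits, record.

Compound 4, `COc1ccc(-c2cc(=O)c3c(OC)cc(OC)cc3n2S(=O)(=O)Cc2ccccc2)cc1`, differs from compound 3 by benzyl in place of 4-chlorophenyl on a sulfonyl sulfur. Neither measured step gives a readable size for a change on the sulfonyl sulfur, and the change from compound 1 to compound 3 on the aromatic nitrogen is equally unreadable. Compound 4 is therefore expected to give 40000 nM in this assay, within 10000 nM to 100000 nM, most likely again reported only as a limit. The step that the limit leaves unreadable from compound 3 to compound 4 expected from this estimate is none beyond the scatter.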

Compound 4, half-maximal effective concentration: > 34400 nM
Compound 4: no number, only a limit; the forecaster's own chance of this, stated with the estimate: 75%; the middle value lies beyond the limit too.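

In this assay compound 4 gives > 34400 nM and that is only a limit. Among these compounds, no step from compound 1, compound 2 or compound 3 to compound 4 can be read, because each has a limit at both ends: the limit of > 34400 nM in this assay, at which 2 of the 4 values shown sit. The compounds shown leave open at what concentration any of the four acts on these cells, and whether the group on the sulfonyl sulfur matters.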